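This account rests on a few compounds, and the source may have more. Where it says the series, first, only, none or still open, it means among the compounds named here.

Measured in an ADME assay on Caco-2 cells (Homo sapiens) for permeability, in the apical to basolateral direction; a lower number here means that the compound crosses the layer more slowly, a higher number that the compound crosses the layer faster:
- Compound 1 `Cc1nc(-c2nc[nH]n2)ccc1-c1cnc2c(n1)N(CC1CCOCC1)C(=O)CN2`: 9.7 10^-6 cm/s
- Compound 2 `Cc1nc(-c2nc[nH]n2)ccc1-c1cnc2c(n1)N(C(C)C)C(=O)CN2`: 37.6 10^-6 cm/s

Compound 2 has the higher of the two numbers. Compound 3 `COCCN1C(=O)CNc2ncc(-c3ccc(-c4nc[nH]n4)nc3C)nc21` differs from it in one place, with 2-methoxyethyl in place of isopropyl on an amide-type nitrogen in a ring. Among the compounds with values here, only one measured step bears on this nitrogen, namely a 3.9-fold higher number from compound 1 to compound 2 (0.59 log units; beyond the scatter), with isopropyl in place of (oxan-4-yl)methyl. Like (oxan-4-yl)methyl, 2-methoxyethyl contains oxygen, so a smaller move in the opposite direction is expected in this assay, though one step is thin evidence. The expected change is a 1.9-fold lower number from compound 2 to compound 3 (0.27 log units; within the scatter). For compound 3 the estimated value is 20 10^-6 cm/s, with an expected range from 10 10^-6 cm/s to 38 10^-6 cm/s.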

Compound 3, apparent permeability: 5 10^-6 cm/s
Compound 3: the middle estimate sits 4.0-fold (0.60 log units) above what was measured; the measured number lies below the stated range.
By their numbers in this assay, from the lowest: compounds 3 and 1 (each within the scatter of the next); then compound 2.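

On this amide-type nitrogen in a ring, 2-methoxyethyl in place of isopropyl gives a 7.5-fold lower number from compound 2 to compound 3 (0.88 log units; beyond the scatter) in this assay and so places compound 3 with compound 1, as a 1.9-fold lower number from compound 1 to compound 3 (0.29 log units; within the scatter) leaves these two oxygen-bearing chains unseparated. Of the three compounds, only compound 2, with isopropyl, stands apart. Nothing shown gives a reason for this difference.
As far as these compounds go, whether an oxygen-free longer chain, such as n-butyl, would stay with isopropyl remains open, as does whether an amine in the chain would fall with the two ethers.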